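Flavone series: aryl para substituent swap, antiproliferative read-out

The compounds below may be only part of what the source reports. "The series", "measured", "known", "first", "only" and "open" are said of these compounds alone.

Within the data shown here, compound 2 `COc1cc(OC)c2c(=O)cc(-c3ccc(OCC(O)CN4CCCC4)cc3)oc2c1` is the only member of the series with a number so far: in a functional assay (Homo sapiens) for antiproliferative activity, read by resazurin assay, with a stated time of 48 h, tested at 20 uM (on this read-out lower numbers stand for a weaker effect and higher numbers for a stronger effect at the one concentration tested), compound 2 gives 57%. Among the measured compounds shown here, compound 1 `COc1cc(OC)c2c(=O)cc(-c3ccc(OC4CCNCC4)cc3)oc2c1` has no result recorded in this assay, where compound 1 stands as "not determined" (no result reported), so no step between measured compounds can be computed and compound 2 stands alone, neither high nor low by comparison.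

Compound 3 `COc1cc(OC)c2c(=O)cc(-c3ccc(-c4ccc(F)nc4)cc3)oc2c1` is the next member to be measured. The change from compound 2 is 6-fluoropyridin-3-yl in place of 2-hydroxy-3-(pyrrolidin-1-yl)propoxy on an aromatic carbon.

For the measured compounds named here, with a single measured value and no measured step on which to rest, the step of a number 7 percentage points lower from compound 2 to compound 3 (within the scatter) is expected to be small, either direction, and likely within the usual scatter of repeated measurements. The estimate for compound 3 in this assay is accordingly placed near the value of compound 2, at 50%, with a wide range from 25% to 75% reflecting the lack of any second data point.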

Compound 3, a percentage reported as inhibition, at one concentration (the size of the read-out at that concentration, not a potency): 19%
Compound 3: the middle estimate sits 31 percentage points above what was measured; measured number outside the range, below it.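

The aromatic carbon carrying this substituent is not indifferent to the group placed there: in this assay, exchanging 2-hydroxy-3-(pyrrolidin-1-yl)propoxy for 6-fluoropyridin-3-yl gives a number 38 percentage points lower from compound 2 to compound 3 (beyond the scatter). The exchange alters several things at once, as a non-aromatic five-membered ring and a hydrogen-bond donor leave while a six-membered aromatic ring enters, so this single step cannot assign the difference to any one of them. No measurement at hand accounts for the size of the step.

Still open, as far as these compounds go, is which part of the leaving group matters: the hydroxyl, the pyrrolidine nitrogen or the chain itself. A 3-(pyrrolidin-1-yl)propoxy chain without the hydroxyl, a morpholine in place of the pyrrolidine, or a pyridin-3-yl group without fluorine would each separate these contributions.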